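The source may hold more compounds than are shown below. What is called first, only, known or untested is meant among the compounds shown, and "the series" means these compounds.

Of the compounds shown here, three built on one shared core have been measured in a functional assay on MGC-803 cells (Homo sapiens) for antiproliferative activity, read by CCK-8 assay, with a stated time of 72 h, tested at 8 uM; a lower number here means a weaker effect, a higher number a stronger effect of the compound at the concentration tested. Compound 1 `Nc1ccccc1NC(=O)c1ccc(CSC(=S)N2CCN(Cc3ccncc3)CC2)cc1` gives 79.3%; compound 2 `Nc1ccccc1NC(=O)c1ccc(CSC(=S)N2CCN(c3ncccn3)CC2)cc1` gives 64.8%; compound 3 `N#Cc1ccc(N2CCN(C(=S)SCc3ccc(C(=O)Nc4ccccc4N)cc3)CC2)cc1` gives 37.6%. Compound 3 thus stands lowest of the three: its nearest neighbour is compound 2, and a number 27.2 percentage points lower from compound 2 to compound 3 (beyond the scatter); further off lies compound 1, with a number 41.7 percentage points lower from compound 1 to compound 3 (beyond the scatter). Between the other two, a number 14.5 percentage points lower from compound 1 to compound 2 (beyond the scatter).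

Compound 4 `Cc1ccc(N2CCN(C(=S)SCc3ccc(C(=O)Nc4ccccc4N)cc3)CC2)cc1` has not yet been measured in this assay. It differs from compound 3 in one place, (methyl in place of cyano on an aromatic carbon), the aromatic carbon that carried the cyano now bearing a methyl.

None of the three measured steps tests this change. All of them exchange the whole group on the amine nitrogen in the ring, among (pyridin-4-yl)methyl, pyrimidin-2-yl and 4-cyanophenyl, and the only one that touches a 4-cyanophenyl, the step from compound 2 to compound 3, says nothing about what the cyano contributes on its own. For the measured compounds named here, there is no measured step to lean on, so the size and direction of any change remain open. Against that background an estimated step of a number 7.4 percentage points higher from compound 3 to compound 4 (within the scatter) is taken, small and within the scatter, in this assay. Compound 4 is expected to give 45%, within a range from 25% to 65%.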

Compound 4, a percentage reported as inhibition, at one concentration (the size of the read-out at that concentration, not a potency): 19.8%
The estimate for compound 4 lay 25.2 percentage points above the measured number; measured number below the stated range.
By their numbers in this assay, from the lowest: compound 4; then compound 3; then compound 2; then compound 1.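

In this assay, the group on the aromatic carbon para to a large group proves to count on its own: with methyl in place of cyano and all else held, the read-out shows a number 17.8 percentage points lower from compound 3 to compound 4 (beyond the scatter), the first measure of this position, which the earlier exchanges of the whole group on the ring amine nitrogen could not isolate. The 4-methylphenyl group also widens the distance from the other two groups on that nitrogen, with a number 45 percentage points lower from compound 2 to compound 4 (beyond the scatter) and a number 59.5 percentage points lower from compound 1 to compound 4 (beyond the scatter), which leaves compound 4 as the weakest of the four at the concentration tested and shows that a phenyl ring on that nitrogen does not fix the read-out by itself. Nothing at hand bears on why the methyl and cyano compounds part in this way.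

With only cyano and methyl shown on this carbon, it remains open how a methoxy group, an amine, a chlorine atom or a carboxylic acid there would compare with either. Since each number comes from a single concentration, the compounds also leave open whether these differences would hold as differences in potency.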